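Replacing the Amide-Bearing Cyclohexyl with a Hydroxylated One

The source may report more compounds than this note shows. Statements on the series, on what has been measured and on what is new or still open speak of the compounds shown alone.

Measured so far, in an assay on isolated protein for inhibition of protein kinase C theta type (Homo sapiens), read by TR-FRET, with a stated time of 2 h; on this read-out lower numbers stand for stronger inhibition and higher numbers for weaker inhibition:
- compound 1, `N#Cc1cnc(NCc2cnccc2C(F)(F)F)cc1NC[C@H]1C[C@H](O)C1`, gives 700 nM
- compound 2, `N#Cc1cnc(NCc2cnccc2C(F)(F)F)cc1N[C@H]1CC[C@@H](C(N)=O)CC1`, gives 7 nM

Compound 2 holds the lower of the two numbers in this assay, with compound 1 sitting well apart from it. Among the measured compounds shown here, the only step available, a 100-fold lower number from compound 1 to compound 2 (2.00 log units; beyond the scatter), shows how strongly the group on the ring nitrogen can move the result.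

Compound 3, `CC1(C)C[C@H](Nc2cc(NCc3cnccc3C(F)(F)F)ncc2C#N)CC[C@H]1O`, is the next variation: 4-hydroxy-3,3-dimethylcyclohexyl in place of 4-carbamoylcyclohexyl on a nitrogen on an aromatic ring. The carbamoyl group leaves and a hydroxyl enters on a ring that also carries two methyl groups. For the measured compounds named here, no measured pair isolates this exact swap; compound 1 carries a hydroxyl on a smaller ring with a linker and gave the weaker number, but that change also altered the ring itself. A moderate weakening is therefore expected, a 4.3-fold higher number from compound 2 to compound 3 (0.63 log units; beyond the scatter), and compound 3 is estimated at 30 nM, within 7 nM to 150 nM.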

Compound 3, half-maximal inhibitory concentration: 100 nM
Estimate against measurement, compound 3: 3.3-fold (0.52 log units) below; the measured number falls inside the stated range.
By their numbers in this assay, from the lowest: compound 2; then compound 3; then compound 1.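

In this assay, the group on this nitrogen now gives three clearly separated levels, with a 14-fold higher number from compound 2 to compound 3 (1.15 log units; beyond the scatter) and a 7.0-fold lower number from compound 1 to compound 3 (0.85 log units; beyond the scatter). Among the compounds shown here, a hydroxyl-bearing group here can therefore give a much lower number than the one seen for compound 1, yet 4-hydroxy-3,3-dimethylcyclohexyl still does not match the 4-carbamoylcyclohexyl of compound 2. Nothing available explains either difference.

The step from compound 2 to compound 3 removes the carbamoyl group, adds a hydroxyl and adds two methyl groups in one change, so the three compounds cannot show how much each part contributes. A plain 4-hydroxycyclohexyl would separate the hydroxyl from the two methyl groups, while a 4-aminocyclohexyl or a cyclohexyl bearing a carboxylic acid would show how other groups compare with the carbamoyl group.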